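The source may report more compounds than this note shows. Statements on the series, on what has been measured and on what is new or still open speak of the compounds shown alone.

Among the measured compounds shown here, in a functional assay on SMMC-7721 cells (Homo sapiens) for cytotoxicity, read by MTT assay, with a stated time of 24 h (on this read-out lower numbers stand for stronger inhibition and higher numbers for weaker inhibition), compound 3 (`COc1cc(/C=C2\CN(S(=O)(=O)c3ccc(NC(C)=O)cc3)C/C(=C\c3ccccc3F)C2=O)cc(OC)c1OC`) gives 3920 nM as the lowest of the three numbers so far, with compound 1 (`CC(=O)Nc1ccc(S(=O)(=O)N2C/C(=C\c3cccc([N+](=O)[O-])c3)C(=O)/C(=C/c3cccc([N+](=O)[O-])c3)C2)cc1`) at 8420 nM and compound 2 (`CC(=O)Nc1ccc(S(=O)(=O)N2C/C(=C\c3cccc([N+](=O)[O-])c3)C(=O)/C(=C/c3ccccc3F)C2)cc1`) at 10200 nM on the higher side. Compound 4 (`COc1cc(/C=C2\CN(S(=O)(=O)c3ccc(NC(C)=O)cc3)C/C(=C\c3cccc([N+](=O)[O-])c3)C2=O)cc(OC)c1OC`) is still to be measured. It carries 3-nitrophenyl in place of 2-fluorophenyl on a double-bonded chain carbon bound to a double-bonded ring carbon and keeps the 3,4,5-trimethoxyphenyl of compound 3.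

The same exchange, read in reverse, has been measured once (a 1.2-fold higher number from compound 1 to compound 2 (0.08 log units; within the scatter)) and stays within the scatter. In that pair, however, the group that stays in place is 3-nitrophenyl rather than 3,4,5-trimethoxyphenyl, so the precedent is a single and imperfect one. The other measured step (a 2.6-fold lower number from compound 2 to compound 3 (0.42 log units; beyond the scatter)) is modest and beyond the scatter, but it concerns the group that does not change here, so it sets the level of compound 3 rather than the size of this step.

In this assay no step beyond the scatter is therefore expected, and the estimated step (a 1.2-fold lower number from compound 3 to compound 4 (0.06 log units; within the scatter)) is small. Compound 4 is estimated at 3400 nM with an expected range of 1700 nM to 7000 nM for this measurement.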

Compound 4, half-maximal inhibitory concentration: 1950 nM
The estimate for compound 4 lay 1.7-fold (0.24 log units) above the measured number, and the stated range covers the measured number.
By their numbers in this assay, from the lowest: compounds 4 and 3 (each within the scatter of the next); then compounds 1 and 2 (each within the scatter of the next).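

In this assay, the exchange of 2-fluorophenyl for 3-nitrophenyl at this position can now be read with a second partner, giving a 2.0-fold lower number from compound 3 to compound 4 (0.30 log units; within the scatter), and the two readings of this change agree: the same change on two cores in this assay, a 1.2-fold higher number (0.08 log units; within the scatter) from compound 1 to compound 2 and a 2.0-fold higher number (0.30 log units; within the scatter) from compound 4 to compound 3, 1.7-fold (0.22 log units) apart, within the scatter of two such steps. Placing 3,4,5-trimethoxyphenyl on a double-bonded chain carbon bound to a double-bonded ring carbon gives a 5.2-fold lower number from compound 2 to compound 4 (0.72 log units; beyond the scatter) when it replaces 2-fluorophenyl and a 4.3-fold lower number from compound 1 to compound 4 (0.64 log units; beyond the scatter) when it replaces 3-nitrophenyl. The lower number that comes with 3,4,5-trimethoxyphenyl in place of 3-nitrophenyl now appears with either 2-fluorophenyl or 3-nitrophenyl as the partner group: the same change on two cores in this assay, a 2.6-fold lower number (0.42 log units; beyond the scatter) from compound 2 to compound 3 and a 4.3-fold lower number (0.64 log units; beyond the scatter) from compound 1 to compound 4, 1.7-fold (0.22 log units) apart, within the scatter of two such steps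

Only these three aromatic groups are shown at this place, so it remains open whether an amine, a carboxylic acid or a longer chain there would keep, raise or lower the number. The rest of the shared core does not vary among the four compounds, and all readings come from this assay, so neither the contribution of that core nor the behaviour of the series in other cells can be judged.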